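Sulfonamide aryl swap in a piperidine aminophenyl ketone series

The compounds below may be only part of what the source reports. "The series", "measured", "known", "first", "only" and "open" are said of these compounds alone.

Compound 1 `COc1ccc(S(=O)(=O)N2CCC(CCC(=O)c3cc(Cl)c(N)cc3OC)CC2)cc1` carries the sulfonyl directly on the piperidine nitrogen; in an assay on brain for displacement of a labelled ligand from 5-hydroxytryptamine receptor 4 (Cavia porcellus), with a stated time of 30 min, in the presence of a further agent that is not named here (a higher number here means a weaker inhibitor, a lower number a stronger inhibitor), compound 1 has no result recorded, the entry reading "not determined" (no result reported). Compound 2 `COc1ccc(S(=O)(=O)NCCN2CCC(CCC(=O)c3cc(Cl)c(N)cc3OC)CC2)cc1Cl` gives 22.5 nM in this assay, the lowest of the two numbers available. Compound 3 `COc1ccc(S(=O)(=O)NCCCN2CCC(CCC(=O)c3cc(Cl)c(N)cc3OC)CC2)cc1` gives 26 nM in this assay, and the gap to compound 2 lies within the scatter, so no order between compound 2 and compound 3 can be read from these two numbers.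

Compound 4 `COc1cc(N)c(Cl)cc1C(=O)CCC1CCN(CCNS(=O)(=O)c2ccc(NC(C)=O)cc2)CC1` keeps the rest of compound 2 and differs in one place: 4-acetamidophenyl in place of 3-chloro-4-methoxyphenyl on a sulfonyl sulfur. Among the compounds with values here, no measured pair with this kind of change exists in the set, so the step has to be judged without precedent. Within the data shown here, with only two numbers in hand and both close together, a small shift toward a weaker inhibitor is expected, but not one clearly beyond the scatter. The estimate for compound 4 in this assay is 35 nM, within 12 nM to 110 nM, an expected step of a 1.6-fold higher number from compound 2 to compound 4 (0.19 log units; within the scatter).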

Compound 4, inhibition constant: 7.7 nM
Compound 4: the middle estimate sits 4.5-fold (0.66 log units) above what was measured; measured number below the stated range.
By their numbers in this assay, from the lowest: compound 4; then compounds 2 and 3 (each within the scatter of the next).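

Within the data shown here, on a sulfonyl sulfur whose other neighbour is the sulfonamide nitrogen, 4-acetamidophenyl in place of 3-chloro-4-methoxyphenyl gives in this assay a 2.9-fold lower number from compound 2 to compound 4 (0.47 log units; beyond the scatter); this is the first one-place step, and it shows that this aryl group affects the number. The change removes the chlorine and the methoxy group and adds an acetamido group with a hydrogen-bond donor, so the step cannot be assigned to any one of these features. No measurement bears on why the number falls.

On these data alone, it remains open whether a 4-aminophenyl or a plain 4-methoxyphenyl on the chain of compound 2 would match compound 4, which would show which part of the swap carries the step. As far as these compounds go, it also remains open whether 4-acetamidophenyl holds its number on a propyl chain.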